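Working notes: from compound 1 to compound 4

The source may hold more compounds than are shown below. What is called first, only, known or untested is meant among the compounds shown, and "the series" means these compounds.

Values in an ADME assay on microsomes from liver (Homo sapiens) for metabolic stability, read by LC-MS, with a stated time of 30 min, tested at 1 uM (on this read-out higher numbers stand for a more stable compound and lower numbers for a less stable compound), are as follows.
- compound 1 `O=C(NCc1ccc(S(=O)(=O)c2cccc(F)c2)cc1)c1cc2cnccc2[nH]1` gives 79%
- compound 2 `O=C(NCc1ccc(S(=O)(=O)c2ccccc2)cc1)c1ccc2nncn2c1` gives 96%
- compound 3 `O=C(NCc1ccc(S(=O)(=O)c2cc(F)cc(F)c2)cc1)c1cnc2nccn2c1` gives 78%

Compound 1 stands level with compound 3, within the scatter, while compound 2 lies higher, beyond it. Compound 4 `Cc1cccc(S(=O)(=O)c2ccc(CNC(=O)c3cc4cnccc4[nH]3)cc2)c1` keeps the core of compound 1 and carries methyl in place of fluoro on an aromatic carbon, so 3-fluorophenyl becomes 3-methylphenyl. Going by the values given here, no two measured compounds differ in one place only, so no measured step sizes this change. A small downward step, within the scatter, is expected in this assay. The expected step is a number 6 percentage points lower from compound 1 to compound 4 (within the scatter), a rough estimate. For compound 4 the estimated value is 73% (range 58% to 87%).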

Compound 4, percent of the compound remaining: 49%
Estimate against measurement, compound 4: 24 percentage points above; the measured number lies below the stated range.
By their numbers in this assay, from the lowest: compound 4; then compounds 3 and 1 (each within the scatter of the next); then compound 2.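

In this assay, this place on the ring is not a neutral one: methyl in place of fluoro on an aromatic carbon gives a number 30 percentage points lower from compound 1 to compound 4 (beyond the scatter). Going by these compounds alone, this is the first one-place comparison, and it shows that exchanging one heavy atom for one heavy atom, with no ring, donor or acceptor count changed, is enough to move this read-out. Nothing at hand bears on what lies behind the step.

Open, on these data alone, is whether a chloro, methoxy or ethyl group at this place would follow fluoro or methyl. Also open, as far as these compounds go, is whether the same change would give a similar step on the other cores, those of compound 2 and compound 3.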